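This account rests on a few compounds, and the source may have more. Where it says the series, first, only, none or still open, it means among the compounds named here.

Measured compounds:
- compound 1 `CC1=CC[C@H](C(=O)N(c2cc(C#CC(C)(C)C)sc2C(=O)O)[C@H]2CC[C@](O)(CO[C@H]3CCOC3)CC2)CC1`: > 20000 nM
- compound 2 `CC(C)(C)C#Cc1cc(N(C(=O)[C@H]2CC[C@H](C)CC2)[C@H]2C[C@@H](Oc3cccnc3)C2)c(C(=O)O)s1`: > 20000 nM
- compound 3 `CC(C)N(C(=O)C1CCCCCC1)c1cc(C#CC(C)(C)C)sc1C(=O)O`: > 20000 nM

All three were tested in an ADME assay on MT4 cells (Homo sapiens) for cytotoxicity, with a stated time of 5 days; a lower number here means that less compound is tolerated, a higher number that more compound is tolerated. For compound 1 the result > 20000 nM is a limit of the assay rather than a number. For compound 2 the result > 20000 nM is likewise a limit. For compound 3 the result > 20000 nM is a limit too. Compound 2 therefore stands nowhere in particular among these three: each of them sits at the limit of > 20000 nM in this assay, at which 3 of the 3 values shown sit, and no one of them can be called more or less tolerated than another on this evidence.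

Compound 4 `CC(C)(C)C#Cc1cc(N(C(=O)[C@H]2CC[C@H](C)CC2)[C@H]2CC[C@H](O)CC2)c(C(=O)O)s1` has not yet been tested in this assay. It differs from compound 2 at a single place: 4-hydroxycyclohexyl in place of 3-((pyridin-3-yl)oxy)cyclobutyl on an amide-type nitrogen. Going by the values given here, since all three measured compounds, compound 1, compound 2 and compound 3, reached the same limit, there is no measured step on which to judge this change, and none beyond the scatter is expected from compound 2 to compound 4.

Compound 4 is accordingly expected to reach the same limit, with an estimated value of 25000 nM, in the range 10000 nM to 80000 nM. The expected step that the limit leaves unreadable from compound 2 to compound 4 is thus estimated to be essentially none.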

Compound 4, half-maximal cytotoxic concentration: > 20000 nM
Compound 4 gave a limit, no number (the forecaster's own chance of this, stated with the estimate: 85%); the middle value lies beyond the limit too.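

In this assay, compound 2 and compound 4 each give only a limit and not a number, so no step can be read from one to the other for the change on the amide-type nitrogen: the limit of > 20000 nM in this assay, at which 4 of the 4 values shown sit. The compounds shown leave open what concentration of any of them the cells would fail to tolerate, and whether this change of group alters that concentration.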